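This account rests on a few compounds, and the source may have more. Where it says the series, first, only, none or still open, it means among the compounds named here.

Measured in an ADME assay on microsomes from liver (Homo sapiens) for metabolic stability; on this read-out lower numbers stand for a shorter-lived compound and higher numbers for a longer-lived compound:
- Compound 1 `CC(C)C(c1ccc(-c2ccc3cccc(F)c3c2)[nH]c1=O)N1CCN/C1=N\C#N`: 0.632 h
- Compound 2 `CC(C)C(c1nnc[nH]1)c1ccc(-c2ccc3cccc(F)c3c2)[nH]c1=O`: 0.905 h
- Compound 3 `CC(C)C(/C=C1/CCNC1=O)c1ccc(-c2ccc3cccc(F)c3c2)[nH]c1=O`: 0.987 h

For the measured compounds named here, compound 3 stands level with the other two within the scatter, as no measured step in this small set goes beyond it. Its closest neighbour is shown by a 1.1-fold higher number from compound 2 to compound 3 (0.04 log units; within the scatter), and its widest gap by a 1.6-fold higher number from compound 1 to compound 3 (0.19 log units; within the scatter).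

Compound 4 `CC(C)C(/C=C1\CCNC1=O)c1ccc(-c2ccc3cccc(F)c3c2)[nH]c1=O` is the next case. The change is the two compounds have the same atoms and bonds; at least one stereo element is drawn with a configuration in one of them and without one in the other: 1 of 2 stereo elements differ; a double bond is drawn Z in compound 3 and E in compound 4: a double bond is drawn Z in compound 3 and E in compound 4.

Going by the values given here, no measured pair isolates this kind of change, so the evidence is indirect. The three measured steps replace the whole group on a saturated chain carbon bound to an aromatic carbon and a saturated chain carbon. Even so, a 1.4-fold higher number from compound 1 to compound 2 (0.16 log units; within the scatter), like the two steps above, stays within the scatter. A change of double-bond drawing alone is therefore not expected to move this assay by more than those larger replacements did, though the data cannot rule it out.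

The expected result is no shift beyond the scatter, in either direction, with a 1.1-fold lower number from compound 3 to compound 4 (0.04 log units; within the scatter) as the estimated step. The estimate for compound 4 is 0.9 h, with an expected range of 0.5 h to 1.6 h.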

Compound 4, half-life: 0.713 h
The estimate for compound 4 lay 1.3-fold (0.10 log units) above the measured number; low and high end bracket the measured number.
By their numbers in this assay, from the lowest: compounds 1, 4, 2 and 3 (each within the scatter of the next).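

Changing the double-bond drawing from Z to E leaves atoms and bonds untouched, and in this assay it gives a 1.4-fold lower number from compound 3 to compound 4 (0.14 log units; within the scatter), so this position shows no step beyond the scatter for a geometry change alone. Compound 4 also stays level with the compounds carrying the other two groups at this place, with a 1.3-fold lower number from compound 2 to compound 4 (0.10 log units; within the scatter) and a 1.1-fold higher number from compound 1 to compound 4 (0.05 log units; within the scatter), so the switch to E does not separate the group of 7 heavy atoms from the five-membered aromatic ring with 3 hetero atoms or from the group of 8 heavy atoms. The pair still needs a caution on how firmly its geometry is defined: the fact that one of compounds 3 and 4 is drawn with a defined configuration and the other without, at the place where they differ.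

On these data alone, it remains open whether any group on this saturated chain carbon, such as a carboxylic acid or an amine, would move the half-life beyond the scatter. With the shared core constant across all four compounds, the compounds shown also leave open whether a change to that core, such as a hydroxyl group in place of the fluorine, would shift this assay.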